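The source may hold more compounds than are shown below. What is called first, only, known or untested is meant among the compounds shown, and "the series" means these compounds.

In an ADME assay on HFF cells (Homo sapiens) for cytotoxicity, with a stated time of 8 days (a lower number here means that less compound is tolerated, a higher number that more compound is tolerated), compound 3 `C=CCOc1nc(N)nc2c1ncn2/C=C1/CC1(CO)CO`, with allyloxy on the shared core, gives > 300000 nM, which is a limit and not a number. Compound 2 `Nc1nc(OCC(F)(F)F)c2ncn(/C=C3/CC3(CO)CO)c2n1` also gives only a limit, > 300000 nM. Compound 3 therefore stands at the limit of > 300000 nM in this assay, at which 2 of the 3 values shown sit. Going by the values given here, compound 1 `CNc1nc(N)nc2c1ncn2/C=C1/CC1(CO)CO`, with methylamino at the same place, is the only one with a number, 265000 nM.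

Compound 4 `CN(C)c1nc(N)nc2c1ncn2/C=C1/CC1(CO)CO` carries dimethylamino in place of allyloxy on an aromatic carbon. The closest measured change runs the other way, from methylamino to allyloxy, and is an at least 1.1-fold higher number from compound 1 to compound 3 (0.05 log units; that floor lies within the scatter). The change to 2,2,2-trifluoroethoxy is an at least 1.1-fold higher number from compound 1 to compound 2 (0.05 log units; that floor lies within the scatter). The remaining comparison is a step that the two limits leave unreadable from compound 2 to compound 3. Neither step from compound 1 shows a change beyond the scatter, so the estimate leans on compound 1 at 265000 nM, whose methylamino is the nearest measured group to dimethylamino. The expected change is small and towards a lower number, if it can be read at all: an at least 1.2-fold lower number from compound 3 to compound 4 (0.09 log units; that floor lies within the scatter). For compound 4 the expected value is 240000 nM, with an estimated range of 110000 nM to 300000 nM.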

Compound 4, half-maximal cytotoxic concentration: > 300000 nM
Compound 4: only a limit was reported; the forecaster's own chance of this, stated with the estimate: 40%; middle value at least 1.2-fold (0.09 log units) from the limit.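

In this assay, the limit is no longer reached only with allyloxy and 2,2,2-trifluoroethoxy at this position: dimethylamino, which puts nitrogen rather than oxygen on the aromatic carbon, reaches it too. Methyl in place of hydrogen on that nitrogen gives an at least 1.1-fold higher number from compound 1 to compound 4 (0.05 log units; that floor lies within the scatter), so this change does not separate compound 4 from compound 1. The steps from compound 2 and from compound 3 to compound 4 cannot be read, with both ends of each step resting on the same limit: the limit of > 300000 nM in this assay, at which 3 of the 4 values shown sit.

From the compounds shown here alone, the order among compound 2, compound 3 and compound 4 therefore stays open. Also open, going by these compounds, is whether a free amino group, a carboxylic acid or a longer chain at this position would give a readable number, and how that number would stand against compound 1 at 265000 nM.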